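This account rests on a few compounds, and the source may have more. Where it says the series, first, only, none or still open, it means among the compounds named here.

In a functional assay on MDA-MB-231 cells (Homo sapiens), read by microscopy and transwell migration, with a stated time of 24 h (a lower number here means a stronger inhibitor, a higher number a weaker inhibitor), compound 1 `CCCCn1c(-c2ccc(C)cc2C)cs/c1=N\C(=O)c1ccccc1` gives 196 nM. Compound 2 `COc1cc(-c2csc(NC(=O)c3ccccc3)n2)cc(OC)c1OC` reads > 50000 nM, which is a limit of the assay and not a number. Compound 3 `COc1ccc(C(=O)Nc2nc(-c3cc(OC)c(OC)c(OC)c3)cs2)cc1OC` carries one change relative to compound 2, on a carbonyl carbon whose other neighbours are an amide-type nitrogen: 3,4-dimethoxyphenyl in place of phenyl (3,4-dimethoxyphenyl in place of phenyl on a carbonyl carbon). Within the data shown here, no measured pair yet shows what a swap of this kind does, so there is no earlier step to serve as a guide. The expectation therefore starts from compound 2 alone, whose reading of > 50000 nM is again only a limit. A small move towards stronger inhibition is expected, an at least 1.6-fold lower number from compound 2 to compound 3 (0.22 log units; that floor lies within the scatter), and the assay may well report only a limit again. For compound 3 the estimated value is 30000 nM, with an expected range from 8000 nM to 50000 nM.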

Compound 3, half-maximal inhibitory concentration: > 25000 nM
Compound 3 gave a limit, no number; the forecaster's own chance of this, stated with the estimate: 60%; the middle value is on the limit's open side.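

Among these compounds, compound 2 and compound 3 each give only a limit in this assay, not a number, so no step between them can be read. From the compounds shown here alone, whether 3,4-dimethoxyphenyl in place of phenyl on a carbonyl carbon changes inhibition at all, and in which direction, stays open.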